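This account rests on a few compounds, and the source may have more. Where it says the series, first, only, none or still open, it means among the compounds named here.

Measured compounds:

compound 1, `O=c1ccc(-c2ccccc2)nn1CCCCNC(=S)NC1CCCCC1`: 18.1%
compound 2, `CC(C)(C)/N=C(\S)NCCCCn1nc(-c2ccccc2)ccc1=O`: 33.6%
compound 3, `C=CCNC(=S)NCCCCn1nc(-c2ccccc2)ccc1=O`: 27.1%

In a functional assay on the whole organism with Rattus norvegicus as the target, at a dose of 100 mg/kg (a higher number here means more inhibition at the dose given (going by the name of the read-out), a lower number less inhibition), compound 3 stands second highest of the three numbers. Its nearest neighbour is compound 2, a number 6.5 percentage points lower from compound 2 to compound 3 (within the scatter), and its furthest is compound 1, a number 9 percentage points higher from compound 1 to compound 3 (within the scatter); neither gap separates compound 3 from the other two.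

Compound 4, `CC(C)C/N=C(\S)NCCCCn1nc(-c2ccccc2)ccc1=O`, is to be measured. Relative to compound 3 the change is a group of 7 heavy atoms (5 carbon, 1 nitrogen, 1 sulfur; no ring) in place of a group of 6 heavy atoms (4 carbon, 1 nitrogen, 1 sulfur; no ring), on an amine nitrogen.

Among the compounds with values here, two measured steps concern the same amine nitrogen. The step of a number 15.5 percentage points higher from compound 1 to compound 2 (beyond the scatter) is the only one in the set that goes beyond the scatter, and it is still modest. The step of a number 6.5 percentage points lower from compound 2 to compound 3 (within the scatter), which is the closer analogue of the present change in size (a chain group exchanged for another chain group, with one heavy atom difference), stays within the scatter. Taken together, exchanging one acyclic group for another on this nitrogen has so far not moved this assay by more than the scatter, so for compound 4 no step beyond the scatter is expected in either direction; the estimated step of a number 2.9 percentage points higher from compound 3 to compound 4 (within the scatter) is small.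

Compound 4 is therefore expected to give about 30% in this assay, with a likely range from 15% to 45%.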

Compound 4, a percentage reported as inhibition, in the whole organism at one dose (the size of the read-out at that dose, not a potency): 35.8%
Compound 4: middle estimate off by 5.8 percentage points, on the low side; the measured number falls inside the stated range.
By their numbers in this assay, from the lowest: compounds 1, 3, 2 and 4 (each within the scatter of the next, the first and the last beyond it).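

In this assay, isobutyl in place of tert-butyl on the double-bonded nitrogen gives a number 2.2 percentage points higher from compound 2 to compound 4 (within the scatter), and the comparison with the allyl compound gives a number 8.7 percentage points higher from compound 3 to compound 4 (within the scatter), so the three open-chain groups now shown on this nitrogen fall within the scatter of one another and can't be ordered. Against the cyclohexyl compound the result gives a number 17.7 percentage points higher from compound 1 to compound 4 (beyond the scatter), a second step beyond the scatter alongside a number 15.5 percentage points higher from compound 1 to compound 2 (beyond the scatter), though the separation from cyclohexyl is not general: a number 9 percentage points higher from compound 1 to compound 3 (within the scatter) stays within the scatter. No evidence is available on what lies behind these differences.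

On these data alone, it remains open whether a phenyl or benzyl group, a longer chain or a group carrying a carboxylic acid on this nitrogen would stay with the open-chain compounds or move beyond the scatter in either direction. With a single dose in this assay, these numbers give the size of the inhibition at that dose and leave open whether the same grouping would hold at other doses.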